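A few compounds are considered here, and "the series" means these few. Any claim that something is new, unique, unknown or untested is made for them only; others in the source may bear on it.

Compounds measured so far:
compound 1 `O=C(Nc1ccccc1O)C1CCc2ccccc2N1C(=O)c1ccccc1Cl` with 44200 nM in a functional assay on ACHN cells (Homo sapiens) for cytotoxicity, read by sulforhodamine B assay, with a stated time of 72 h; on this read-out lower numbers stand for stronger inhibition of growth and higher numbers for weaker inhibition of growth
compound 2 `O=C(Nc1ccccc1O)C1CCc2ccccc2N1` with 3990 nM in this assay

Compound 2 carries the lowest of the two numbers; its nearest neighbour is compound 1, and the gap between them is given by an 11-fold lower number from compound 1 to compound 2 (1.04 log units; beyond the scatter), which lies well beyond the scatter. The unmeasured compound 3 `O=C(Nc1ccccc1O)C1CCc2ccccc2N1C(=O)c1cccc(Cl)c1` is reached from compound 2 by one change: (3-chlorophenyl)carbonyl in place of hydrogen on a nitrogen on an aromatic ring in a ring. For the measured compounds named here, the one measured step that bears on this is an 11-fold lower number from compound 1 to compound 2 (1.04 log units; beyond the scatter), which describes the reverse move, the removal of the closely related (2-chlorophenyl)carbonyl group from the same nitrogen. Putting a chlorophenylcarbonyl group back on that nitrogen is therefore expected to push the number up by a large step, with the position of the chlorine on the ring being the only untested point. For compound 3 the expected step is an 8.8-fold higher number from compound 2 to compound 3 (0.94 log units; beyond the scatter). Compound 3 is estimated to give 35000 nM in this assay, with a plausible range from 10000 nM to 120000 nM.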

Compound 3, concentration for 50% growth inhibition: 17200 nM
Compound 3: the middle estimate sits 2.0-fold (0.31 log units) above what was measured; the range from low to high includes it.
By their numbers in this assay, from the lowest: compound 2; then compound 3; then compound 1.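

In this assay the rise in the number on adding a group to this nitrogen is not confined to the 2-chlorophenyl case: (3-chlorophenyl)carbonyl also gives a 4.3-fold higher number from compound 2 to compound 3 (0.63 log units; beyond the scatter) and so weakens growth inhibition, though this step is modest where the earlier one was large. The position of the chlorine matters too, since moving it alone gives a 2.6-fold lower number from compound 1 to compound 3 (0.41 log units; beyond the scatter) while the rest of the structure stays the same. No measurement shown here accounts for either step.

The compounds shown leave open how a carbonyl group without chlorine on its phenyl ring, such as plain benzoyl, would compare on this nitrogen. They also leave open whether a smaller group, such as acetyl or methyl, would raise the number as far.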